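Swapping the aryl group at a level pair

A few compounds are considered here, and "the series" means these few. Any claim that something is new, unique, unknown or untested is made for them only; others in the source may bear on it.

In a physicochemical assay for lipophilicity, measured as chromatographic lipophilicity, at pH 7.4 (a lower number here means a more polar compound, a higher number a more lipophilic compound), compound 1 `COc1cc(-c2nnc3n2CCCC3(OC)c2ccc(Cl)c(Cl)c2)ccc1-c1cnc(C)o1` gives 3.7 and compound 2 `COc1cc(-c2nnc3n2CCCC3(c2ccc(Cl)c(Cl)c2)C(C)(C)O)ccc1-c1cnc(C)o1` gives 3.7 so these two stand level. Compound 3 `COc1cc(-c2nnc3n2CCCC3(Oc2ccc(F)c(F)c2)C(C)(C)O)ccc1-c1cnc(C)o1` keeps the 1-hydroxy-1-methylethyl group of compound 2 but carries 3,4-difluorophenoxy in place of 3,4-dichlorophenyl on a saturated ring carbon. In counted terms the change is 3,4-difluorophenoxy in place of 3,4-dichlorophenyl on a saturated ring carbon and the rest of the structure stays the same. Going by the values given here, the only measured step is no change at the digits printed from compound 1 to compound 2 (within the scatter) and it replaced methoxy, not the 3,4-dichlorophenyl group. Among the compounds with values here, no measured pair tests the new swap directly, so the expectation rests on the structural change alone and remains loose. A modest downward step of a number 0.40 log units lower from compound 2 to compound 3 (beyond the scatter) is expected in this assay for this swap. Compound 3 is estimated at 3.3 with 2.9 to 3.7 as the likely range.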

Compound 3, distribution coefficient: 2.8
Compound 3: the middle estimate sits 0.50 log units above what was measured, and the stated range ends above it.
By their numbers in this assay, from the lowest: compound 3; then compounds 1 and 2 (each within the scatter of the next).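

With the 1-hydroxy-1-methylethyl group held fixed, putting 3,4-difluorophenoxy in place of 3,4-dichlorophenyl on this saturated ring carbon gives, in this assay, a number 0.90 log units lower from compound 2 to compound 3 (beyond the scatter), whereas replacing methoxy gave no change at the digits printed from compound 1 to compound 2 (within the scatter) and so left the reading level. The new swap makes two changes at once, fluorine for chlorine and an entering oxygen, and these compounds cannot separate them. Nothing at hand explains the size of this step. Still open, on these data alone, is whether the halogens or the oxygen account for the step, a question that 3,4-dichlorophenoxy or 3,4-difluorophenyl at this carbon would help to answer. Also open, as far as these compounds go, is how a group of another kind, such as an amine or a carboxylic acid, would read in this assay at this place.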